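The source may hold more compounds than are shown below. What is called first, only, known or untested is meant among the compounds shown, and "the series" means these compounds.

Measured in a functional assay (Homo sapiens) for inhibition; a lower number here means a stronger inhibitor, a higher number a weaker inhibitor:

Compound 1 `CSc1ccc(CSc2nc(-c3ccc(Cl)cc3)c(-c3ccncc3)[nH]2)cc1`: 2200 nM
Compound 2 `CSc1ccc(CSc2nc(-c3ccc(Br)cc3)c(-c3ccncc3)[nH]2)cc1`: 2400 nM
Compound 3 `CSc1ccc(CSc2nc(-c3ccccc3)c(-c3ccncc3)[nH]2)cc1`: not yet measured

Compound 2, at 2400 nM, stands level with compound 1, at 2200 nM, and the two numbers lie within the scatter of each other. Compound 3 follows from compound 2 by one change, hydrogen in place of bromo on an aromatic carbon, so that 4-bromophenyl becomes phenyl. Going by the values given here, the one measured step that bears on this is a 1.1-fold higher number from compound 1 to compound 2 (0.04 log units; within the scatter), bromo in place of chloro on an aromatic carbon. Among the compounds with values here, that step exchanges one halogen for another, and no measured compound carries hydrogen at this place, so it is only a loose guide. No shift beyond the scatter is therefore expected in this assay, and the direction is uncertain, with the estimated step being a 1.3-fold higher number from compound 2 to compound 3 (0.10 log units; within the scatter). For compound 3 the estimate is 3000 nM, with an expected range from 1000 nM to 9000 nM.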

Compound 3, half-maximal inhibitory concentration: 72500 nM
Compound 3: the middle estimate sits 24-fold (1.38 log units) below what was measured; the whole stated range lies below it.
By their numbers in this assay, from the lowest: compounds 1 and 2 (each within the scatter of the next); then compound 3.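

In this assay the substituent at this place proves far more important than the exchange of chloro for bromo suggested: hydrogen in place of bromo gives a 30-fold higher number from compound 2 to compound 3 (1.48 log units; beyond the scatter), and hydrogen in place of chloro gives a 33-fold higher number from compound 1 to compound 3 (1.52 log units; beyond the scatter), whereas the halogen exchange itself gives only a 1.1-fold higher number from compound 1 to compound 2 (0.04 log units; within the scatter). Among these three compounds, then, the large difference lies between a halogen and hydrogen on this aromatic carbon, para to a large group, and not between the two halogens, since compound 1 and compound 2 stand level. Nothing available here accounts for the size of this loss.

Going by these compounds, it remains open whether fluoro, methyl, methoxy or trifluoromethyl at this place would stay level with compound 1 and compound 2 or fall nearer compound 3. On these data alone, whether the same gap appears with other changes elsewhere on the shared core is also open.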